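Moving the Methyl on the Piperidine Ring

A few compounds are considered here, and "the series" means these few. Any claim that something is new, unique, unknown or untested is made for them only; others in the source may bear on it.

In a functional assay on HCT-116 cells (Homo sapiens) for cytotoxicity, read by WST assay, with a stated time of 72 h (on this read-out lower numbers stand for stronger inhibition and higher numbers for weaker inhibition), compound 1 `COc1cc2c(Nc3nc4ccc(C(=O)Nc5c(C)cc(C)cc5C)cc4s3)ncnc2cc1OCCCN1CCC(C)CC1` gives 6900 nM. Compound 2 `COc1cc2c(Nc3nc4ccc(C(=O)Nc5c(C)cccc5C)cc4s3)ncnc2cc1OCCCN1CCCCC1C` gives only > 100000 nM, which is a limit of this assay and not a number. Compound 3 `COc1cc2c(Nc3nc4ccc(C(=O)Nc5c(C)cccc5C)cc4s3)ncnc2cc1OCCCN1CCC(C)CC1` differs from compound 2 by 4-methylpiperidin-1-yl in place of 2-methylpiperidin-1-yl on a saturated chain carbon, three bonds along the chain from an oxygen on an aromatic ring. Among the measured compounds shown here, no measured pair of compounds shows this change on its own, and compound 2 offers no number as a starting point, so the step is uncertain. The expected step from compound 2 to compound 3 is estimated as an at least 3.3-fold lower number from compound 2 to compound 3 (0.52 log units; beyond the scatter), in the direction of stronger inhibition. Compound 3 is expected to give about 30000 nM, with a plausible range from 6000 nM to 150000 nM.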

Compound 3, half-maximal inhibitory concentration: > 100000 nM
Compound 3: a limit, no number; the forecaster's own chance of this, stated with the estimate: 35%; middle value at least 3.3-fold (0.52 log units) away from the limit.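

Compound 3 gives > 100000 nM, again a limit of this assay and not a number, so 4-methylpiperidin-1-yl in place of 2-methylpiperidin-1-yl yields no readable value here. The change between compound 2 and compound 3 cannot be read, because both sit at the same limit: the limit of > 100000 nM in this assay, at which 2 of the 3 values shown sit.

The readable result is an at least 14-fold higher number from compound 1 to compound 3 (1.16 log units; beyond the scatter), with hydrogen in place of methyl on an aromatic carbon, so with 4-methylpiperidin-1-yl held fixed, that single methyl marks a large difference.

Still open, as far as these compounds go, is whether the position of the piperidine methyl matters when that aromatic methyl is present, and how a morpholine or an unsubstituted piperidine would behave on the same chain.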